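Swapping the Amide Substituent: Compound 1 to Compound 3

The compounds below may be only part of what the source reports. "The series", "measured", "known", "first", "only" and "open" are said of these compounds alone.

Compound 1 `COc1ccc2c(=O)c(/C=C/C(=O)Nc3cc(C)ccc3C)coc2c1` was tested in a functional assay (QGY7701 cells, Homo sapiens) for inhibition, read by MTT assay, with a stated time of 48 h; a lower number here means a stronger inhibitor, a higher number a weaker inhibitor. In this assay compound 1 gives > 100000 nM, which is a limit of the assay rather than a number. Compound 2 `COc1ccc(NC(=O)/C=C/c2coc3cc(O)ccc3c2=O)cc1` also returns only a limit, giving > 100000 nM in this assay. Both measured values therefore rest at the limit of > 100000 nM in this assay, at which 2 of the 2 values shown sit, so compound 1 cannot be ranked against compound 2. Compound 3 `COc1ccc(CNC(=O)/C=C/c2coc3cc(OC)ccc3c2=O)cc1` carries 4-methoxybenzyl in place of 2,5-dimethylphenyl on an amide-type nitrogen, 4-methoxybenzyl in place of 2,5-dimethylphenyl on an amide-type nitrogen. With nothing measured beyond the limit, the expected step of a number no higher from compound 1 to compound 3 (the limit leaves the size open) is none beyond the scatter. Compound 3 is estimated at 100000 nM, with a range from 30000 nM to 300000 nM.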

Compound 3, half-maximal inhibitory concentration: 15700 nM
For compound 3 the middle estimate is 6.4-fold (0.80 log units) above the measured one; the whole stated range lies above it.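

Replacing 2,5-dimethylphenyl with 4-methoxybenzyl on the amide-type nitrogen gives an at least 6.3-fold lower number from compound 1 to compound 3 (0.80 log units; beyond the scatter). Among these compounds, this shows that the group at this position can bring the read-out in this assay off the limit, which the earlier compounds could not show. Compound 3 is the only one of the three with a number rather than a limit: the limit of > 100000 nM in this assay, at which 2 of the 3 values shown sit.

Which part of 4-methoxybenzyl carries the step stays open. A plain benzyl or a 2-phenylethyl group on the same nitrogen would speak to that.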